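The source may report more compounds than this note shows. Statements on the series, on what has been measured and on what is new or still open speak of the compounds shown alone.

Measured so far in a functional assay on HepG2 cells (Homo sapiens) for inhibition, read by MTT assay, with a stated time of 48 h; on this read-out lower numbers stand for stronger inhibition and higher numbers for weaker inhibition:
- compound 1 `CCOC(=O)C1=C(N/C=N/c2nnc(S(N)(=O)=O)s2)Nc2[nH]nc(C)c2C1c1ccc(N(C)C)cc1` gives 38100 nM
- compound 2 `CCOC(=O)C1=C(N/N=C(\C#N)C(N)=O)Nc2[nH]nc(C)c2C1c1ccc(N(C)C)cc1` gives 48400 nM
- compound 3 `CCOC(=O)C1=C(N/N=C(/C(C)=O)C(=O)OCC)Nc2[nH]nc(C)c2C1c1ccc(N(C)C)cc1` gives only a limit, > 100000 nM

Compound 1 stands lowest of the two numbers shown, with compound 2 nearest: a 1.3-fold higher number from compound 1 to compound 2 (0.10 log units; within the scatter). Compound 3 sits at the assay limit, (the limit of > 100000 nM in this assay, at which 1 of the 3 values shown sits), and so gives no number; the step of an at least 2.6-fold higher number from compound 1 to compound 3 (0.41 log units; beyond the scatter) is therefore a lower bound on the change.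

Compound 4 `CCOC(=O)C1=C(N/N=C(/C(=O)Br)c2ccc(Cl)cc2)Nc2[nH]nc(C)c2C1c1ccc(N(C)C)cc1` is the next variation on compound 1 at the same position: a group of 12 heavy atoms (8 carbon, 1 nitrogen, 1 oxygen, 1 chlorine, 1 bromine; one six-membered aromatic ring of carbon only) in place of a group of 11 heavy atoms (3 carbon, 4 nitrogen, 2 oxygen, 2 sulfur; one five-membered aromatic ring with 3 hetero atoms), on an amine nitrogen. Both measured steps from compound 1 replace this same group on the amine nitrogen, and neither gave a lower number: one stayed within the scatter, the other rose beyond it. A third, larger group at this position is accordingly expected to leave the number where it is or push it higher. Compound 4 is expected to show a 1.7-fold higher number from compound 1 to compound 4 (0.23 log units; within the scatter). The estimate for compound 4 in this assay is 65000 nM, with a range from 25000 nM to 160000 nM, and a real chance that only a limit is reported.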

Compound 4, half-maximal inhibitory concentration: 50300 nM
The estimate for compound 4 lay 1.3-fold (0.11 log units) above the measured number; measured number inside the range.
By their numbers in this assay, from the lowest: compounds 1, 2 and 4 (each within the scatter of the next). At a limit, above all of these: compound 3.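

In this assay, a group with one six-membered aromatic ring of carbon only, carrying chlorine and bromine, gives a 1.3-fold higher number from compound 1 to compound 4 (0.12 log units; within the scatter) and a 1.0-fold higher number from compound 2 to compound 4 (0.02 log units; within the scatter), so on this amine nitrogen a larger group without hydrogen-bond donors does not separate from the groups of compound 1 and compound 2. Set against the group with no ring, the reading is an at least 1.9-fold lower number from compound 3 to compound 4 (0.29 log units; that floor lies within the scatter), a floor only, so this pair is not firmly separated. Compound 3 gives a limit and not a number: the limit of > 100000 nM in this assay, at which 1 of the 4 values shown sits.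

The compounds shown leave open whether a simple amine or a carboxylic acid on this amine nitrogen would bring the number clearly below that of compound 1. They also leave open whether the chlorine or the bromine of compound 4 matters to its number.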